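Swapping the Aryl Group: Expected Cytotoxicity of Compound 3

A few compounds are considered here, and "the series" means these few. Any claim that something is new, unique, unknown or untested is made for them only; others in the source may bear on it.

For the measured compounds named here, compound 2 `COc1cc(C2=C(c3cc(C)c(OC)c(C)c3)C(O[SiH2]C(C)(C)C)CC2=O)cc(OC)c1OC` is the only member of this small set with a definite number in an ADME assay on HEK293 cells (Homo sapiens) for cytotoxicity, read by MTT assay, with a stated time of 72 h; on this read-out lower numbers stand for stronger inhibition and higher numbers for weaker inhibition: compound 2 gives 29 ug/mL. Compound 1 `COC(=O)c1cc(C2=C(c3cc(OC)c(OC)c(OC)c3)C(=O)CC2O[SiH2]C(C)(C)C)ccc1OC` sits at the limit of > 100 ug/mL in this assay, at which 1 of the 2 values shown sits, so the value of compound 1, > 100 ug/mL, is a limit rather than a number. Going by the values given here, the one measured step, an at least 3.4-fold lower number from compound 1 to compound 2 (0.53 log units; beyond the scatter), shows that exchanging the aryl group on the double-bonded ring carbon can move the read-out beyond the scatter. Compound 3 `COc1ccc(C2=C(c3cc(OC)c(OC)c(OC)c3)C(=O)CC2O[SiH2]C(C)(C)C)cc1O` carries a further exchange at that same position: 3-hydroxy-4-methoxyphenyl in place of 4-methoxy-3,5-dimethylphenyl on a double-bonded ring carbon. Among the compounds with values here, the single step available does not settle a direction for this new aryl group, and a return toward the limit cannot be ruled out. Compound 3 is therefore expected at 50 ug/mL, in a range from 20 ug/mL to 120 ug/mL. That estimate corresponds to an expected step of a 1.7-fold higher number from compound 2 to compound 3 (0.24 log units; within the scatter).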

Compound 3, half-maximal inhibitory concentration: 42 ug/mL
For compound 3 the middle estimate is 1.2-fold (0.08 log units) above the measured one, and the stated range covers the measured number.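

In this assay the exchange of 4-methoxy-3,5-dimethylphenyl for 3-hydroxy-4-methoxyphenyl on a double-bonded ring carbon gives a 1.4-fold higher number from compound 2 to compound 3 (0.16 log units; within the scatter) and so does not separate these two aryl groups. For the compounds shown here, the earlier compounds showed only that an exchange at this position could move the read-out, whereas hydroxy in place of methoxycarbonyl on an aromatic carbon now gives an at least 2.3-fold lower number from compound 1 to compound 3 (0.37 log units; beyond the scatter) and ties a step beyond the scatter to a single group on that aryl ring. Going by these compounds, compound 1 still gives a limit and not a number, so the full size of that step remains unknown: (the limit of > 100 ug/mL in this assay, at which 1 of the 3 values shown sits).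

The compounds shown leave open how an amine or a carboxylic acid in place of the hydroxy on that aromatic carbon would read. They also leave open whether a longer chain in place of the methoxy on that aryl ring would keep the read-out where compound 3 stands.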